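Replacing 3,5-dimethylphenyl with 2-vinylphenyl on a shared core

The compounds below may be only part of what the source reports. "The series", "measured", "known", "first", "only" and "open" are said of these compounds alone.

Measured in a functional assay on KB cells (Homo sapiens) for cytotoxicity; on this read-out lower numbers stand for an effect already at smaller amounts and higher numbers for an effect only at larger amounts of compound:
- compound 1 `COC1=C(C)C(=O)/C(=C(O)/C=C/c2ccccc2OC)C(=O)C1(C)C` gives 3.3 ug/mL
- compound 2 `COC1=C(C)C(=O)/C(=C(O)/C=C/c2ccccc2C)C(=O)C1(C)C` gives 4.1 ug/mL
- compound 3 `COC1=C(C)C(=O)/C(=C(O)/C=C/c2cc(C)cc(C)c2)C(=O)C1(C)C` gives 3.1 ug/mL

Compound 3 stands level with the other two compounds. Both a 1.1-fold lower number from compound 1 to compound 3 (0.03 log units; within the scatter) and a 1.3-fold lower number from compound 2 to compound 3 (0.12 log units; within the scatter) lie within the scatter, as does a 1.2-fold higher number from compound 1 to compound 2 (0.09 log units; within the scatter).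

Compound 4 `C=Cc1ccccc1/C=C/C(O)=C1/C(=O)C(C)=C(OC)C(C)(C)C1=O` has not yet been measured. It keeps the shared core and differs from compound 3 at one place: 2-vinylphenyl in place of 3,5-dimethylphenyl on a double-bonded chain carbon bound to a double-bonded chain carbon. Here 2-vinylphenyl comes in place of 3,5-dimethylphenyl on a double-bonded chain carbon bound to a double-bonded chain carbon.

The most relevant evidence comes from exchanges at this same place: a 1.3-fold lower number from compound 2 to compound 3 (0.12 log units; within the scatter), involving 2-methylphenyl, and a 1.1-fold lower number from compound 1 to compound 3 (0.03 log units; within the scatter), involving 2-methoxyphenyl. Among the measured compounds shown here, neither exchange goes beyond the scatter, although no measured compound carries a vinyl group. The expected 1.1-fold higher number from compound 3 to compound 4 (0.04 log units; within the scatter) is therefore estimated to stay within the scatter, with no direction favoured. For compound 4 the estimate is 3.4 ug/mL, with an expected range from 1.7 ug/mL to 6.5 ug/mL.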

Compound 4, concentration for half-maximal effect: 1.9 ug/mL
Compound 4: middle estimate off by 1.8-fold (0.25 log units), on the high side; measured number inside the range.
By their numbers in this assay, from the lowest: compounds 4, 3, 1 and 2 (each within the scatter of the next, the first and the last beyond it).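

In this assay this position now gives its first step beyond the scatter: vinyl in place of methyl on an aromatic carbon yields a 2.2-fold lower number from compound 2 to compound 4 (0.33 log units; beyond the scatter) and stands as a modest change. The other two exchanges stay within the scatter, with a 1.6-fold lower number from compound 3 to compound 4 (0.21 log units; within the scatter) for 2-vinylphenyl in place of 3,5-dimethylphenyl and a 1.7-fold lower number from compound 1 to compound 4 (0.24 log units; within the scatter) where vinyl replaces methoxy, so compound 4 stands apart from compound 2 alone. Nothing at hand accounts for this one step.

Open, from the compounds shown here alone, is whether the double bond matters or only the size of the group, which ethyl in place of vinyl would help to separate. Also open, going by these compounds, is how an amine, a carboxylic acid or a longer chain would fare at this place.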